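Replacing the acetyl benzyl amide by a cyclohexyl urea

The source may report more compounds than this note shows. Statements on the series, on what has been measured and on what is new or still open speak of the compounds shown alone.

Measured compounds:
compound 1, `CCCCc1ccc(CNS(=O)(=O)c2ccccc2)c(=O)n1Cc1ccc(-c2ccccc2-c2nn[nH]n2)cc1`, gives 25.2% in a functional assay on the whole organism (artery) for inhibition, with Rattus norvegicus as the target, at a dose of 3 mg/kg by the intraduodenal route; on this read-out higher numbers stand for more inhibition at the one dose given (going by the name of the read-out) and lower numbers for less inhibition
compound 2, `CCCCc1ccc(CN(Cc2ccccc2)C(C)=O)c(=O)n1Cc1ccc(-c2ccccc2-c2nn[nH]n2)cc1`, gives 76.3% in this assay

Going by the values given here, compound 2 stands highest of the two numbers, and the only measured step, a number 51.1 percentage points higher from compound 1 to compound 2 (beyond the scatter), was large. Compound 3, `CCCCc1ccc(CNC(=O)NC2CCCCC2)c(=O)n1Cc1ccc(-c2ccccc2-c2nn[nH]n2)cc1`, differs from compound 2 in one place: (cyclohexylcarbamoyl)amino in place of acetyl(benzyl)amino on a saturated chain carbon bound to an aromatic carbon. Among the compounds with values here, that earlier step bears on compound 3 only in that it touched the same position; no measured pair shows this group. A moderate fall is therefore expected, a number 26.3 percentage points lower from compound 2 to compound 3 (beyond the scatter), with wide uncertainty. For compound 3 the estimate is 50%, between 20% and 80%.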

Compound 3, a percentage reported as inhibition, in the whole organism at one dose (the size of the read-out at that dose, not a potency): 0%
Beside the measured number, compound 3's estimate is 50 percentage points above it; measured number outside the range, below it.
By their numbers in this assay, from the lowest: compound 3; then compound 1; then compound 2.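

With the cyclohexyl urea, this position proves able to lose all of the inhibition at the one dose given in this assay: compound 3 gives 0%, with a number 76.3 percentage points lower from compound 2 to compound 3 (beyond the scatter). The urea also ranks under the phenylsulfonyl group on the same amine nitrogen, with a number 25.2 percentage points lower from compound 1 to compound 3 (beyond the scatter). Nothing measured here accounts for this loss.

The compounds shown do not separate the urea link from the cyclohexyl ring. A phenyl urea or an N-cyclohexyl acetamide at this position would remain to be judged.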